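Three close relatives and one added methyl

This account rests on a few compounds, and the source may have more. Where it says the series, first, only, none or still open, it means among the compounds named here.

- Compound 1 `COc1ccc(/C=C/c2cc(OC)c(OC)c(OC)c2-c2ccc(OC)cc2)cc1`: 34000 nM
- Compound 2 `COc1ccc(/C=C/c2cc(OC)c(OC)c(OC)c2-c2ccccc2)cc1`: 51000 nM
- Compound 3 `COc1cc(/C=C/c2ccccc2)c(-c2ccccc2)c(OC)c1OC`: 82000 nM

All three values come from a functional assay on DU-145 cells (Homo sapiens) for cytotoxicity, read by MTT assay, with a stated time of 48 h; a lower number here means a stronger inhibitor, a higher number a weaker inhibitor. Compound 3 gives the highest of the three numbers, yet only its gap to compound 1 goes beyond the scatter. Compound 4 `COc1cc(/C=C/c2ccc(C)cc2)c(-c2ccccc2)c(OC)c1OC` differs from compound 3 by one change, methyl in place of hydrogen on an aromatic carbon. The nearest guide is a 1.6-fold higher number from compound 2 to compound 3 (0.21 log units; within the scatter), a swap of methoxy for hydrogen at that same spot. A like swap elsewhere gave a 1.5-fold higher number from compound 1 to compound 2 (0.18 log units; within the scatter). Neither step leaves the scatter, so no step beyond the scatter is expected in this assay. The expected step is a 1.3-fold lower number from compound 3 to compound 4 (0.10 log units; within the scatter). Compound 4 is estimated at 65000 nM, with an expected range from 30000 nM to 140000 nM.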

Compound 4, half-maximal inhibitory concentration: 101000 nM
Beside the measured number, compound 4's estimate is 1.6-fold (0.19 log units) below it, within the range that was stated.
By their numbers in this assay, from the lowest: compounds 1, 2, 3 and 4 (each within the scatter of the next, the first and the last beyond it).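

In this assay, a methyl para to a large group gives a 1.2-fold higher number from compound 3 to compound 4 (0.09 log units; within the scatter), so this position accepts the added carbon with no step beyond the scatter. Methyl in place of methoxy at the same spot gives a 2.0-fold higher number from compound 2 to compound 4 (0.30 log units; within the scatter), also within the scatter, so hydrogen, methoxy and methyl cannot be told apart here. No evidence is available on what lies behind these small steps. From the compounds shown here alone, whether an amine or a carboxylic acid at this position would move the number beyond the scatter remains open. So does the effect of a longer chain there.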